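The compounds below may be only part of what the source reports. "The series", "measured", "known", "first", "only" and "open" are said of these compounds alone.

Series notes, cytotoxicity branch. Compound 1 `Cc1cc(-c2ccc3[nH]ccc3c2)cn2c(CSCCc3ccccc3)cnc12` is the reference point. Within the data shown here, in an ADME assay on HEL cells (Homo sapiens) for cytotoxicity, with a stated time of 3 days (on this read-out lower numbers stand for higher toxicity in this test and higher numbers for lower toxicity in this test), compound 1 gives 26 ug/mL, which is the highest of the two numbers measured so far; the nearest is compound 2 `Cc1cc(Sc2ccc(Cl)cc2)cn2c(CSCCc3ccccc3)cnc12`, which in this assay gives 14 ug/mL. The step of a 1.9-fold lower number from compound 1 to compound 2 (0.27 log units; within the scatter) is the only measured one in the set and it is within the scatter.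

The next compound, compound 3 `Cc1cc(Sc2ccc(O)cc2)cn2c(CSCCc3ccccc3)cnc12`, is unmeasured in this assay. Its relation to compound 1 is (4-hydroxyphenyl)sulfanyl in place of 1H-indol-5-yl on an aromatic carbon. Among the measured compounds shown here, the one measured step that bears on this change is a 1.9-fold lower number from compound 1 to compound 2 (0.27 log units; within the scatter), which also exchanged the 1H-indol-5-yl group for a sulfanyl-linked phenyl ring at the same aromatic carbon and produced no step beyond the scatter. On that basis, the expected step of a 1.4-fold lower number from compound 1 to compound 3 (0.16 log units; within the scatter) is likewise none beyond the scatter, with a slight lean towards the lower side seen for compound 2. The estimate for compound 3 in this assay is therefore 18 ug/mL, with a range from 8 ug/mL to 40 ug/mL.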

Compound 3, half-maximal cytotoxic concentration: 100 ug/mL
Compound 3: middle estimate off by 5.6-fold (0.74 log units), on the low side; the measured number lies above the stated range.
By their numbers in this assay, from the lowest: compounds 2 and 1 (each within the scatter of the next); then compound 3.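

At the aromatic carbon two atoms from the ring nitrogen, the sulfanyl-linked phenyl ring does not settle the read-out in this assay on its own: hydroxy in place of chloro on that ring gives a step beyond the scatter (a 7.1-fold higher number from compound 2 to compound 3 (0.85 log units; beyond the scatter)). The exchange of 1H-indol-5-yl for a sulfanyl-linked phenyl ring can therefore stay within the scatter, as with the (4-chlorophenyl)sulfanyl group (a 1.9-fold lower number from compound 1 to compound 2 (0.27 log units; within the scatter)), or pass beyond it towards lower toxicity in this test, as with the (4-hydroxyphenyl)sulfanyl group (a 3.8-fold higher number from compound 1 to compound 3 (0.59 log units; beyond the scatter)). No measurement at hand accounts for the difference between the chloro and hydroxy compounds.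

Still open, going by these compounds, is whether the higher number is particular to hydroxy on this ring, or also comes with a methoxy group, an amine or a carboxylic acid at the same ring carbon. Also open, on these data alone, are whether the hydroxy group gives the same result on a phenyl ring joined directly to the core without the sulfur, and whether the step carries over when the side chain shared by these compounds is replaced by a shorter chain.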